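Swapping cyclopentyl for 3-hydroxypropyl in a cytotoxicity test

A few compounds are considered here, and "the series" means these few. Any claim that something is new, unique, unknown or untested is made for them only; others in the source may bear on it.

In an ADME assay on MT4 cells (Homo sapiens) for cytotoxicity, read by MTT assay, with a stated time of 5 days (on this read-out higher numbers stand for lower toxicity in this test and lower numbers for higher toxicity in this test), compound 3 `COc1cc2cc(C#N)ccc2c(OC)c1Oc1cc(NC2CCCC2)nc(Nc2ccc(C#N)cc2)n1` gives > 125000 nM as a limit of the assay, not a number. Compound 1 `COc1cc2cc(C#N)ccc2c(OC)c1Oc1cc(NCC(C)C)nc(Nc2ccc(C#N)cc2)n1` likewise gives > 125000 nM as a limit. Compound 2 `COc1cc2cc(C#N)ccc2c(OC)c1Oc1cc(NCCCOC(C)C)nc(Nc2ccc(C#N)cc2)n1` gives > 125000 nM as a limit too. All three stand at the limit of > 125000 nM in this assay, at which 3 of the 3 values shown sit, and no number separates them. Compound 4 `COc1cc2cc(C#N)ccc2c(OC)c1Oc1cc(NCCCO)nc(Nc2ccc(C#N)cc2)n1` carries 3-hydroxypropyl in place of cyclopentyl on a nitrogen on an aromatic ring. The measured changes at that nitrogen are a step that the two limits leave unreadable from compound 1 to compound 3 and a step that the two limits leave unreadable from compound 2 to compound 3 and neither offers a size to carry over. No step beyond the scatter, in either direction, is therefore expected in this assay (a number no higher from compound 3 to compound 4 (the limit leaves the size open) as the estimated step). The estimate for compound 4 is 125000 nM (expected range 50000 nM to 250000 nM).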

Compound 4, half-maximal cytotoxic concentration: 23500 nM
Beside the measured number, compound 4's estimate is 5.3-fold (0.73 log units) above it; the measured number lies below the stated range.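

On a nitrogen on an aromatic ring, the side chain can change the number in this assay, and a lower number here means higher toxicity: 3-hydroxypropyl gives an at least 5.3-fold lower number from compound 3 to compound 4 (0.72 log units; beyond the scatter), along with an at least 5.3-fold lower number from compound 1 to compound 4 (0.72 log units; beyond the scatter) and an at least 5.3-fold lower number from compound 2 to compound 4 (0.72 log units; beyond the scatter). The last of these is the narrowest change, since only hydrogen replaces isopropyl on the oxygen, so the free hydroxyl goes with the lower number. Each size is only a minimum, since the other three values are limits, not numbers: the limit of > 125000 nM in this assay, at which 3 of the 4 values shown sit.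

As far as these compounds go, whether an amine or a carboxylic acid in place of the hydroxyl would also lower the number stays open. So does the effect of a longer chain carrying the hydroxyl.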